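Nonyl Chain Extension Across Two Pyridinol Cores

The compounds below may be only part of what the source reports. "The series", "measured", "known", "first", "only" and "open" are said of these compounds alone.

Compound 1 `CCCCCCCCCCc1c(C)c(N(C)C)nc(C)c1O` gives 87% in a functional assay on cells (Lymphocyte), read by a luciferase reporter and ATP content, with a stated time of 48 h, tested at 5 uM; a lower number here means a stronger effect, a higher number a weaker effect of the compound at the concentration tested. Compound 2 `CCCCCCCCCCc1nc(N(C)C)c(C)c(C)c1O` has the same atoms joined differently; the difference between the two cores is not broken down here. In this assay compound 2 gives 89%, within the scatter of compound 1. Compound 3 `CCCCCCCCCCCCCCCCCCCc1c(C)c(N(C)C)nc(C)c1O` carries nonyl in place of hydrogen on a saturated chain carbon, ten or more bonds along the chain from an aromatic carbon and in this assay gives 106%, a step of a number 19 percentage points higher from compound 1 to compound 3 (beyond the scatter). Compound 4 `CCCCCCCCCCCCCCCCCCCc1nc(N(C)C)c(C)c(C)c1O` is not yet measured and differs from compound 2 by nonyl in place of hydrogen on a saturated chain carbon, ten or more bonds along the chain from an aromatic carbon, the same change at the same place as between compound 1 and compound 3. For compound 4 a step of about a number 18 percentage points higher from compound 2 to compound 4 (beyond the scatter) is expected. Among the measured compounds shown here, that expectation rests on the single earlier step of a number 19 percentage points higher from compound 1 to compound 3 (beyond the scatter), so one precedent only. Compound 4 is therefore estimated at 107%, with a likely range from 94% to 120%.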

Compound 4, a percentage reported as activity, at one concentration (the size of the read-out at that concentration, not a potency): 102%
Estimate against measurement, compound 4: 5 percentage points above; low and high end bracket the measured number.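

In this assay the nonyl extension gives a number 13 percentage points higher from compound 2 to compound 4 (beyond the scatter), so on the second core too the longer chain goes with a weaker effect at the concentration tested. Set beside the earlier step, the size of the change also carries over from one core to the other: the same change on two cores in this assay, a number 19 percentage points higher (beyond the scatter) from compound 1 to compound 3 and a number 13 percentage points higher (beyond the scatter) from compound 2 to compound 4, 6 percentage points apart, within the scatter of two such steps

This rests on two matched pairs and a single chain change, so it does not show that the step would hold on other cores or for other chain lengths, nor does it explain the rise.

Open, as far as these compounds go, is whether a shorter chain such as hexyl would move the number on both cores alike. Also open, from the compounds shown here alone, is how a chain ending in an amine or a carboxylic acid would behave.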